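A few compounds are considered here, and "the series" means these few. Any claim that something is new, unique, unknown or untested is made for them only; others in the source may bear on it.

Measured compounds in this study:
compound 1, `Cc1ccccc1S(=O)(=O)N1CC(O)C[C@H]1C(=O)Nc1ccc(C(=O)O)cc1`: 23.4%
compound 2, `O=C(O)c1ccc(NC(=O)[C@@H]2CC(O)CN2S(=O)(=O)c2ccccc2)cc1`: 27.3%
compound 3, `O=C(O)c1ccc(NC(=O)[C@@H]2CCCN2S(=O)(=O)c2ccccc2)cc1`: 29.4%

All three were tested in a functional assay on the whole organism for inhibition, with Rattus norvegicus as the target, read by paw edema, with stated times of 1 h and 2 h, at a dose of 100 mg/kg by the oral route; on this read-out lower numbers stand for less inhibition and higher numbers for more inhibition at the one dose given (going by the name of the read-out). Compound 1 differs from compound 2 by methyl in place of hydrogen on an aromatic carbon, and this change gave a number 3.9 percentage points lower from compound 2 to compound 1 (within the scatter). Compound 3 differs from compound 2 by hydrogen in place of hydroxy on a saturated ring carbon, and that change gave a number 2.1 percentage points higher from compound 2 to compound 3 (within the scatter). Since every step among the three lies within the scatter, the three compounds cannot be told apart on this read-out.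

Compound 4, `Cc1ccc(S(=O)(=O)N2CCC[C@H]2C(=O)Nc2ccc(C(=O)O)cc2)cc1`, is not yet measured. It differs from compound 3 by methyl in place of hydrogen on an aromatic carbon. This is the same kind of change as that from compound 2 to compound 1, made this time on the core of compound 3, which differs from the core of compound 2 by hydrogen in place of hydroxy on a saturated ring carbon. The place is not identical: in compound 1 the methyl sits ortho to a large group, in compound 4 para to a large group. Among the compounds with values here, the step expected from compound 3 to compound 4 is a number 2.4 percentage points lower from compound 3 to compound 4 (within the scatter), close to zero, because the one earlier instance of this kind of change, a number 3.9 percentage points lower from compound 2 to compound 1 (within the scatter), stayed within the scatter. Compound 4 is therefore expected to give about 27% in this assay, with a likely range from 15% to 40%.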

Compound 4, a percentage reported as inhibition, in the whole organism at one dose (the size of the read-out at that dose, not a potency): 36.3%
Compound 4: the middle estimate sits 9.3 percentage points below what was measured; low and high end bracket the measured number.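

In this assay, methyl in place of hydrogen on an aromatic carbon gave a number 6.9 percentage points higher from compound 3 to compound 4 (within the scatter), and this step does not differ from the one earlier instance of the change: the same change on two cores in this assay, a number 3.9 percentage points lower (within the scatter) from compound 2 to compound 1 and a number 6.9 percentage points higher (within the scatter) from compound 3 to compound 4, 10.8 percentage points apart, within the scatter of two such steps

Within these two instances, the change cannot be told from the scatter on either core, and nothing marks one core as responding differently from the other. This does not show that the change carries over reliably from core to core, since there are only two instances, each read at a single dose, and the methyl sits para to a large group in compound 4 but at another place in compound 1, so core and place cannot be separated.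

The compounds shown leave open whether a longer chain or an amine on that aromatic ring would give a step beyond the scatter. All four keep the carboxylic acid, so they also leave open how an ester in its place would read out.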